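The source may report more compounds than this note shows. Statements on the series, on what has been measured and on what is new or still open speak of the compounds shown alone.

Of the compounds shown here, two have numbers so far in a functional assay on SW620/5-FU cells (Homo sapiens) for cytotoxicity, read by MTT assay, with a stated time of 48 h, in the presence of a further agent that is not named here; on this read-out higher numbers stand for an effect only at larger amounts of compound and lower numbers for an effect already at smaller amounts. There, compound 1 (`Cc1c(Cc2ccccc2)c(NNC(=O)Nc2cc(Cl)nc(Cl)c2)nc2c1cnn2C`) gives 21400 nM and compound 2 (`COc1ccc(-c2cc(NNC(=O)Nc3cc(Cl)nc(OC(C)C)c3)nc3c2cnn3C)cc1`) gives 47100 nM as the higher of the two numbers, and the gap between them lies beyond the scatter. Compound 2 thus stands at the top of this very small set, needing the larger amount of compound for its effect. The two compounds differ in more than one place, so their gap says nothing about any single change.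

The next compound, compound 3 (`CCCOc1cc(NC(=O)NNc2cc(-c3ccc(OC)cc3)c3cnn(C)c3n2)cc(Cl)n1`), has not yet been measured. It holds the same atoms as compound 2, joined differently, with propyl in place of isopropyl on an oxygen on an aromatic ring. For the measured compounds named here, no measured pair isolates this change, so the data offer no direct precedent for it. No step beyond the scatter is therefore expected in this assay, in either direction. The estimated step of a 1.1-fold lower number from compound 2 to compound 3 (0.05 log units; within the scatter) is expected to stay within the scatter. Compound 3 is expected at 42000 nM with an estimated range from 18000 nM to 95000 nM in this measurement.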

Compound 3, half-maximal effective concentration: 37200 nM
Beside the measured number, compound 3's estimate is 1.1-fold (0.05 log units) above it; measured number inside the range.
By their numbers in this assay, from the lowest: compounds 1, 3 and 2 (each within the scatter of the next, the first and the last beyond it).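

For the compounds shown here, the pair of compound 2 and compound 3 is the first in this set to isolate a single change: in this assay, propyl in place of isopropyl on the oxygen on the aromatic ring gives a 1.3-fold lower number from compound 2 to compound 3 (0.10 log units; within the scatter). At this position, therefore, the two three-carbon groups cannot be told apart in this read-out, and going from 2-chloro-6-isopropoxypyridin-4-yl to 2-chloro-6-propoxypyridin-4-yl leaves the number within the usual scatter on the shared core. Nothing measured here offers an explanation for this result.

From the compounds shown here alone, it remains open whether this position would respond to a group further removed from these two, such as a longer chain like butyl on the same oxygen, an amine, or a carboxylic acid. Compound 1 differs from compound 2 and compound 3 in more than one place, so its steps to them cannot be read, and the contribution of any single part of its structure remains unresolved.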